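Changing the Aryl Group on the Amide Nitrogen

The source may report more compounds than this note shows. Statements on the series, on what has been measured and on what is new or still open speak of the compounds shown alone.

Measured in a functional assay on L1210 cells (Mus musculus) for cytotoxicity; on this read-out higher numbers stand for weaker inhibition and lower numbers for stronger inhibition:
compound 1 `COc1ccc(NC(=O)/C=C/C(=O)N2C/C(=C\c3ccc([N+](=O)[O-])cc3)C(=O)/C(=C/c3ccc([N+](=O)[O-])cc3)C2)cc1` gives 2900 nM
compound 2 `O=C(/C=C/C(=O)N1C/C(=C\c2ccc([N+](=O)[O-])cc2)C(=O)/C(=C/c2ccc([N+](=O)[O-])cc2)C1)Nc1ccc([N+](=O)[O-])cc1` gives 1000 nM
compound 3 `Cc1cccc(C)c1NC(=O)/C=C/C(=O)N1C/C(=C\c2ccc([N+](=O)[O-])cc2)C(=O)/C(=C/c2ccc([N+](=O)[O-])cc2)C1` gives 690 nM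

Compound 3 holds the lowest number of the three, yet its gap to compound 2 lies within the scatter, so those two cannot be ordered; only compound 1 stands clearly apart from it. Compound 4 `Cc1ccc(NC(=O)/C=C/C(=O)N2C/C(=C\c3ccc([N+](=O)[O-])cc3)C(=O)/C(=C/c3ccc([N+](=O)[O-])cc3)C2)cc1` arises from compound 3 through (4-methylphenyl in place of 2,6-dimethylphenyl on an amide-type nitrogen). Two measured steps alter the same aryl group on this nitrogen: a 4.2-fold lower number from compound 1 to compound 3 (0.62 log units; beyond the scatter) and a 1.4-fold lower number from compound 2 to compound 3 (0.16 log units; within the scatter). Since every change so far ends at compound 3 with a lower or equal number, leaving it for compound 4 is expected to raise the number modestly, in this assay estimated as a 1.7-fold higher number from compound 3 to compound 4 (0.24 log units; within the scatter). Compound 4 is therefore expected to give about 1200 nM, with a range from 500 nM to 3000 nM.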

Compound 4, half-maximal inhibitory concentration: 4400 nM
Beside the measured number, compound 4's estimate is 3.7-fold (0.56 log units) below it; the whole stated range lies below it.
By their numbers in this assay, from the lowest: compounds 3 and 2 (each within the scatter of the next); then compounds 1 and 4 (each within the scatter of the next).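

The step of a 6.4-fold higher number from compound 3 to compound 4 (0.80 log units; beyond the scatter) shows that the aryl group on this amide-type nitrogen is not interchangeable: 4-methylphenyl does not keep the low number of 2,6-dimethylphenyl. The step of a 4.4-fold higher number from compound 2 to compound 4 (0.64 log units; beyond the scatter) also sets methyl apart from nitro on this ring, while the step of a 1.5-fold higher number from compound 1 to compound 4 (0.18 log units; within the scatter) leaves methyl and methoxy unordered. Nothing available here explains these differences. Still open, from the compounds shown here alone, is whether the number depends on how many methyl groups the ring carries or where they sit, since this step changes both. A plain phenyl ring, or an amine or carboxylic acid on the ring, also remains untested among these compounds.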